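From a free hydroxy to a benzoyloxy group

The source may hold more compounds than are shown below. What is called first, only, known or untested is meant among the compounds shown, and "the series" means these compounds.

In an ADME assay on MCF7 cells (Homo sapiens) for cytotoxicity, read by MTT assay (on this read-out lower numbers stand for an effect already at smaller amounts and higher numbers for an effect only at larger amounts of compound), compound 1 `C=C1CCCC(C)(C)[C@@H]1C[C@@H](O)/C(C)=C/CC[C@@H]1[C@@]2(C)CCCC(C)(C)[C@@H]2CC[C@@]1(C)O` gives > 10 ug/mL as a limit of the assay and not a number. Its position is therefore the limit of > 10 ug/mL in this assay, at which 1 of the 2 values shown sits, and no exact figure exists for it. Going by the values given here, compound 2 `C=C1CCCC(C)(C)[C@@H]1CC(=O)/C(C)=C/CC[C@@H]1[C@@]2(C)CCCC(C)(C)[C@@H]2CC[C@@]1(C)O` gives 8.5 ug/mL in this assay as the only true number so far.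

Compound 3 `C=C1CCCC(C)(C)[C@@H]1C[C@@H](OC(=O)c1ccccc1)/C(C)=C/CC[C@@H]1[C@@]2(C)CCCC(C)(C)[C@@H]2CC[C@@]1(C)O` has not yet been measured. Among the compounds with values here, it differs from compound 1 by benzoyl in place of hydrogen on an oxygen on a saturated carbon as the single change, which in words is benzoyl in place of hydrogen on an oxygen on a saturated carbon, or hydroxy to benzoyloxy.

Within the data shown here, no measured step shows what this change does in this assay on the shared core, so only a modest shift towards smaller amounts is expected, and it may stay within the usual scatter. With compound 2 at 8.5 ug/mL as the one anchor, the estimate stays in that same region. The expected change is an at least 1.1-fold lower number from compound 1 to compound 3 (0.04 log units; that floor lies within the scatter) and remains uncertain. For compound 3 the estimated value is 9 ug/mL with an expected range from 4 ug/mL to 20 ug/mL in this measurement.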

Compound 3, concentration for half-maximal effect: > 10 ug/mL
Compound 3: a limit, no number; the forecaster's own chance of this, stated with the estimate: 40%; middle value at least 1.1-fold (0.04 log units) from the limit.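

In this assay compound 3 gives > 10 ug/mL as a limit and not a number. Compound 1 gives > 10 ug/mL as a limit too. Going by these compounds alone, no step from compound 1 to compound 3 can be read, as both stand at the same mark: the limit of > 10 ug/mL in this assay, at which 2 of the 3 values shown sit. As far as these compounds go, whether hydroxy to benzoyloxy shifts the value at all, and in which direction, stays open.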